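The compounds below may be only part of what the source reports. "The series", "measured", "known", "first", "only" and "open" are said of these compounds alone.

Compound 1 `COc1ccc(-c2nnc(SC/C(=N/O)c3ccccc3)n2-c2ccccc2)cc1`: 58%
Compound 2 `COc1ccc(-c2nnc(SCC(=O)c3ccccc3)n2-c2ccccc2)cc1OC`: 56%
Compound 3 `COc1ccc(-c2nnc(SC/C(=N/O)c3ccccc3)n2-c2ccccc2)cc1OC`: 55%

In a functional assay on the whole organism (strain albino) for inhibition, with Rattus norvegicus as the target, read by paw edema, with a stated time of 1 h, at a dose of 0.28 mmol/kg by the oral route (on this read-out higher numbers stand for more inhibition at the one dose given (going by the name of the read-out) and lower numbers for less inhibition), compound 3 gives 55%; its nearest neighbour is compound 2, with a number 1 percentage points lower from compound 2 to compound 3 (within the scatter), and its furthest is compound 1, with a number 3 percentage points lower from compound 1 to compound 3 (within the scatter), so all three numbers sit within the scatter of one another. Compound 4 `CCn1c(SC/C(=N/O)c2ccccc2)nnc1-c1ccc(OC)c(OC)c1` differs from compound 3 by ethyl in place of phenyl on an aromatic nitrogen. Neither measured step touches the group on the aromatic nitrogen: one concerns the methoxy on an aromatic carbon, the other the group on the saturated chain carbon bound to a sulfur, and both stayed within the scatter. Among the compounds with values here, no measured step therefore bears on this change, and nothing beyond the scatter is expected in this assay. Compound 4 is expected to give 52%, with a range from 40% to 64%. This amounts to an expected a number 3 percentage points lower from compound 3 to compound 4 (within the scatter).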

Compound 4, a percentage reported as inhibition, in the whole organism at one dose (the size of the read-out at that dose, not a potency): 61%
Beside the measured number, compound 4's estimate is 9 percentage points below it; low and high end bracket the measured number.
By their numbers in this assay, from the lowest: compounds 3, 2, 1 and 4 (each within the scatter of the next).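

In this assay, ethyl in place of phenyl on the aromatic nitrogen gives a number 6 percentage points higher from compound 3 to compound 4 (within the scatter). Within the data shown here, this is the first look at this position, and it shows that the inhibition at this one dose holds when the phenyl ring gives way to a small group with no ring. Nothing given here accounts for this result.

Going by these compounds, it remains open whether a longer chain such as butyl, or a chain ending in an amine, would behave like ethyl on this nitrogen. A single change also cannot show whether ethyl would give the same result with other groups on the saturated chain carbon.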